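This account rests on a few compounds, and the source may have more. Where it says the series, first, only, none or still open, it means among the compounds named here.

Measured compounds in a functional assay on HeLa cells (Homo sapiens) for cytotoxicity, read by cell counting, with a stated time of 48 h; a lower number here means that less compound is needed, a higher number that more compound is needed for the effect:
compound 1, `CCCC(=O)O[C@H]1[C@H](O)[C@H](n2ccc(N)nc2=O)O[C@@H]1CO`, gives 0.11 ug/mL
compound 2, `CCCCCCCCCCC(=O)O[C@H]1[C@H](O)[C@H](n2ccc(N)nc2=O)O[C@@H]1CO`, gives 0.04 ug/mL
compound 3, `CC(=O)O[C@H]1[C@H](O)[C@H](n2ccc(N)nc2=O)O[C@@H]1CO`, gives 0.14 ug/mL

Compound 1 stands second highest of the three numbers; compound 3 is nearest, a 1.3-fold higher number from compound 1 to compound 3 (0.10 log units; within the scatter), and compound 2 is furthest, a 2.8-fold lower number from compound 1 to compound 2 (0.44 log units; beyond the scatter). Compound 4, `CCCC(=O)OC[C@H]1O[C@@H](n2ccc(N)nc2=O)[C@@H](O)[C@@H]1OC(=O)CCC`, differs from compound 1 in one place: propylcarbonyl in place of hydrogen on an oxygen on a saturated carbon, so the hydroxymethyl becomes a ((propylcarbonyl)oxy)methyl. Within the data shown here, no measured step adds a second ester; the steps that come closest vary only the single acyl chain, a 2.8-fold lower number from compound 1 to compound 2 (0.44 log units; beyond the scatter) and a 3.5-fold higher number from compound 2 to compound 3 (0.54 log units; beyond the scatter), both modest and both giving lower numbers for the heavier acyl group. Compound 4 is therefore expected to show a modest step down or none beyond the scatter, a 1.6-fold lower number from compound 1 to compound 4 (0.20 log units; within the scatter). Compound 4 is estimated at 0.07 ug/mL, with a range of 0.03 ug/mL to 0.18 ug/mL in this assay.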

Compound 4, concentration for half-maximal effect: 0.11 ug/mL
Compound 4: the middle estimate sits 1.6-fold (0.20 log units) below what was measured; measured number inside the range.
By their numbers in this assay, from the lowest: compound 2; then compounds 1, 4 and 3 (each within the scatter of the next).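

In this assay, propylcarbonyl in place of hydrogen on the oxygen, turning hydroxymethyl into ((propylcarbonyl)oxy)methyl, gives no change at the digits printed from compound 1 to compound 4 (within the scatter) and so no step beyond the scatter. The earlier compounds shown here varied only the single acyl chain, whereas this position carries a second ester with the number unchanged. No supporting data bear on this result.

Open, from the compounds shown here alone, is whether a longer chain on this oxygen would keep the number at this level. Also open, going by these compounds, is how an amine or a carboxylic acid at the end of this acyl group would read.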